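Working notes: triazole ether series, compound 3 to compound 4

This account rests on a few compounds, and the source may have more. Where it says the series, first, only, none or still open, it means among the compounds named here.

Three compounds share one core. Compound 1 `C=CCc1ccc(OCc2cn(-c3ccccc3CO)nn2)c(O)c1` gives 4.2% in a functional assay on HepG2 cells (Homo sapiens) for inhibition, read by MTT assay, with a stated time of 72 h, tested at 30 uM; on this read-out higher numbers stand for more inhibition of growth at the one concentration tested and lower numbers for less inhibition of growth; compound 2 `C=CCc1ccc(OCc2cn(-c3cccc(C#N)c3)nn2)c(O)c1` gives 2.3%; compound 3 `C=CCc1ccc(OCc2cn(-c3ccc(C(=O)c4ccccc4)cc3)nn2)c(O)c1` gives 14.8%, the highest of the three, beyond the scatter above both compound 1 and compound 2. Within the data shown here, the only measured step, a number 1.9 percentage points lower from compound 1 to compound 2 (within the scatter), lies within the scatter. Compound 4 `C=CCc1ccc(OCc2cn(-c3ccc(Br)cc3)nn2)c(O)c1` differs from compound 3 by bromo in place of benzoyl on an aromatic carbon. Among the measured compounds shown here, no measured step removes a benzoyl, so the direction rests on the values alone: compound 1 and compound 2, without a benzoyl, sit well under compound 3, so compound 4 is expected to fall back toward that level, a step of a number 8.8 percentage points lower from compound 3 to compound 4 (within the scatter) downward beyond the scatter. Compound 4 is estimated at 6%, range -5% to 17%.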

Compound 4, percent growth inhibition at one concentration: 8.9%
Estimate against measurement, compound 4: 2.9 percentage points below; the measured number falls inside the stated range.
By their numbers in this assay, from the lowest: compounds 2, 1, 4 and 3 (each within the scatter of the next, the first and the last beyond it).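

Bromo in place of benzoyl on the aromatic carbon gives a step that stays inside the scatter (a number 5.9 percentage points lower from compound 3 to compound 4 (within the scatter)), so this single change does not separate compound 4 from compound 3. Compound 4 is also not separated from the compounds without a benzoyl (a number 6.6 percentage points higher from compound 2 to compound 4 (within the scatter); a number 4.7 percentage points higher from compound 1 to compound 4 (within the scatter)), which leaves it bridging the gap that stood between compound 3 and those two. No supporting measurement bears on this result.

From the compounds shown here alone, whether an amine or a carboxylic acid at this position would read differently from bromo or benzoyl stays open. So does whether any group here lifts growth inhibition clearly above compound 3.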